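This account rests on a few compounds, and the source may have more. Where it says the series, first, only, none or still open, it means among the compounds named here.

Compound 1 `Cc1cc(/C=C/C#N)cc(C)c1Oc1cc(NCCN(C)C)nc(Nc2ccc(C#N)cc2)n1` 3040 nM
Compound 2 `COCCNc1cc(Oc2c(C)cc(/C=C/C#N)cc2C)cc(Nc2ccc(C#N)cc2)n1` 58200 nM

In an ADME assay on MT4 cells (Homo sapiens) for cytotoxicity, read by MTT assay, with a stated time of 5 days (a higher number here means that more compound is tolerated, a lower number that less compound is tolerated), compound 1 gives 3040 nM as the lower of the two numbers, and its gap to compound 2 lies beyond the scatter. Compound 3 `Cc1cc(/C=C/C#N)cc(C)c1Oc1cc(NCCC#N)nc(Nc2ccc(C#N)cc2)n1` has not yet been measured. It carries cyano in place of dimethylamino on a saturated chain carbon, two bonds along the chain from a nitrogen on an aromatic ring. Compound 2 also lacks dimethylamino and gives 58200 nM in this assay, so an upward step beyond the scatter is expected, though this rests on one comparison. The expected change is an 8.2-fold higher number from compound 1 to compound 3 (0.92 log units; beyond the scatter) (an estimate). For compound 3 the estimated value is 25000 nM (expected range 7000 nM to 90000 nM).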

Compound 3, half-maximal cytotoxic concentration: 1000 nM
The estimate for compound 3 lay 25-fold (1.40 log units) above the measured number, outside the stated range (below it).
By their numbers in this assay, from the lowest: compound 3; then compound 1; then compound 2.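

In this assay the change of dimethylamino to cyano on this chain gives a 3.0-fold lower number from compound 1 to compound 3 (0.48 log units; beyond the scatter) and so less compound is tolerated. Losing dimethylamino therefore does not by itself raise the number, and the group that enters counts: compound 2, which also lacks dimethylamino, gives 58200 nM in this assay as its value. No measurement at hand explains this difference.

Still open is where a hydroxyl group, a carboxylic acid or a morpholine on this chain would fall among these numbers. A longer chain carrying cyano or dimethylamino also remains to be placed.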